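The source may hold more compounds than are shown below. What is called first, only, known or untested is meant among the compounds shown, and "the series" means these compounds.

Measured so far:
compound 1 `COc1cc(-c2nn(-c3cccc(NC(=O)c4cccc(C(F)(F)F)c4)c3)cc2-c2ccncc2)ccc1Cl` gives 32100 nM in a functional assay on DU-145 cells (Homo sapiens) for inhibition, read by sulforhodamine B assay, with a stated time of 48 h; a lower number here means a stronger inhibitor of growth, a higher number a weaker inhibitor of growth
compound 2 `O=C(Nc1cccc(-n2cc(-c3ccncc3)c(-c3ccc(Cl)c(O)c3)n2)c1)Nc1cc(C(F)(F)F)cc(C(F)(F)F)c1` gives 5620 nM in this assay

Compound 1 holds the higher of the two numbers in this assay; compound 2 lies a good way lower, beyond the scatter. Compound 3 `COc1cc(-c2nn(-c3cccc(NC(=O)Nc4ccc(Cl)c(C(F)(F)F)c4)c3)cc2-c2ccncc2)ccc1Cl` is not yet measured; it differs from compound 1 by (4-chloro-3-(trifluoromethyl)phenyl)amino in place of 3-(trifluoromethyl)phenyl on a carbonyl carbon. Going by the values given here, no measured pair isolates this change, so its size in this assay is open. A downward step of modest size is expected because compound 2 gives 5620 nM with a substituted phenylamino group likewise on its carbonyl carbon. Compound 3 is expected near 9000 nM, range 2500 nM to 28000 nM. The expected step is a 3.6-fold lower number from compound 1 to compound 3 (0.55 log units; beyond the scatter).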

Compound 3, concentration for total growth inhibition: > 32500 nM
Compound 3 gave a limit, no number; the forecaster's own chance of this, stated with the estimate: 5%; middle value at least 3.6-fold (0.55 log units) from the limit.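

In this assay compound 3 yields a limit of the assay and not a number: the limit of > 32500 nM in this assay, at which 1 of the 3 values shown sits. Going by these compounds alone, this pair gives the first isolated reading at this position: (4-chloro-3-(trifluoromethyl)phenyl)amino in place of 3-(trifluoromethyl)phenyl on a carbonyl carbon gives an at least 1.0-fold higher number from compound 1 to compound 3 (0.00 log units; that floor lies within the scatter). The change therefore brings no lower number here.

On these data alone, how far compound 3 lies beyond its limit stays open, so the full size of the step cannot be read. Also open, as far as these compounds go, is how a methyl group or a plain amino group on the same carbonyl carbon would read in this assay.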